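Benzyl on the sulfonamide nitrogen of the imidazolium oxime series

The source may hold more compounds than are shown below. What is called first, only, known or untested is meant among the compounds shown, and "the series" means these compounds.

Compound 2 `CN(CCCn1cc[n+](C)c1/C=N/O)S(=O)(=O)C(F)(F)F` gives -1.37 in a physicochemical assay for lipophilicity; on this read-out lower numbers stand for lower lipophilicity and higher numbers for higher lipophilicity; compound 1 `C[n+]1ccn(CCCNS(=O)(=O)C(F)(F)F)c1/C=N/O` gives -1.26, and the two lie within the scatter of each other, as a number 0.11 log units lower from compound 1 to compound 2 (within the scatter) shows. Compound 3 `C[n+]1ccn(CCCN(Cc2ccccc2)S(=O)(=O)C(F)(F)F)c1/C=N/O` carries phenyl in place of hydrogen on a saturated chain carbon bound to a sulfonamide nitrogen. Among the compounds with values here, the only measured step, a methyl for hydrogen on the sulfonamide nitrogen, stayed within the scatter, so it bears only loosely on this larger change. A rise beyond the scatter is expected from compound 2 to compound 3 a number 1.57 log units higher from compound 2 to compound 3 (beyond the scatter). Compound 3 is therefore estimated at 0.2, between -0.5 and 0.9.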

Compound 3, distribution coefficient: 0.06
Compound 3: middle estimate off by 0.14 log units, on the high side; measured number inside the range.
By their numbers in this assay, from the lowest: compounds 2 and 1 (each within the scatter of the next); then compound 3.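

Benzyl in place of hydrogen on the sulfonamide nitrogen gives a number 1.32 log units higher from compound 1 to compound 3 (beyond the scatter) in this assay and shows that this position can carry a large step, which the methyl step did not show. Methyl to benzyl gives a number 1.43 log units higher from compound 2 to compound 3 (beyond the scatter) on the same read-out, so substitution on this nitrogen does not by itself set the size of the step. No measurement here accounts for the size of either step.

As far as these compounds go, whether phenethyl, or a benzyl bearing a carboxylic acid, on the sulfonamide nitrogen would give a step of like size stays open.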